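Amide aryl variation on the shared core: compound 4

A few compounds are considered here, and "the series" means these few. Any claim that something is new, unique, unknown or untested is made for them only; others in the source may bear on it.

Compound 3 `CS(=O)(=O)c1ccc(C(=O)Nc2ccc(Cl)c(-c3nnc4c(Cl)cccn34)c2)cc1` reaches only a limit in a functional assay on A549 cells (Homo sapiens) for antiproliferative activity, read by MTT assay, with a stated time of 72 h; a higher number here means a weaker inhibitor, a lower number a stronger inhibitor: compound 3 gives > 100000 nM, a limit of the assay and not a number. Compound 1 `O=C(Nc1ccc(Cl)c(-c2nnc3c(Cl)cccn23)c1)c1cccnc1` also sits at a limit, and in this assay compound 1 gives > 100000 nM. Among the compounds with values here, compound 2 `O=C(Nc1ccc(Cl)c(-c2nnc3c(Cl)cccn23)c1)c1ccc(Cl)cc1` is the only one with a read number, giving 73600 nM in this assay. Two of the three values stand at the limit of > 100000 nM in this assay, at which 2 of the 3 values shown sit, so compound 3 is not separated from compound 1 at all, and the shown step from compound 2 leaves it within the scatter.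

The move to compound 4 `O=C(Nc1ccc(Cl)c(-c2nnc3c(Cl)cccn23)c1)c1cccnc1Cl` is 2-chloropyridin-3-yl in place of 4-(methylsulfonyl)phenyl on a carbonyl carbon. The measured steps that bear on it are a step that the two limits leave unreadable from compound 1 to compound 3 and an at least 1.3-fold higher number from compound 2 to compound 3 (0.13 log units; that floor lies within the scatter), both changing the group on the carbonyl carbon, neither with a size readable beyond the scatter. The remaining step, an at least 1.3-fold lower number from compound 1 to compound 2 (0.13 log units; that floor lies within the scatter), also stays at its floor within the scatter. Compound 4 carries the pyridin-3-yl of compound 1 with a chloro added. Compound 1 stands at a limit. No step beyond the scatter is therefore expected for a number no higher from compound 3 to compound 4 (the limit leaves the size open). Compound 4 is estimated at 100000 nM, within 40000 nM to 300000 nM, with a limit read the likely outcome.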

Compound 4, half-maximal inhibitory concentration: 35800 nM
Compound 4: middle estimate off by 2.8-fold (0.45 log units), on the high side, outside the stated range (below it).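

Chloro in place of hydrogen on an aromatic carbon gives an at least 2.7-fold lower number from compound 1 to compound 4 (0.44 log units; beyond the scatter) in this assay and is the first change at this place on the carbonyl carbon with a step readable beyond the scatter. The same group, 2-chloropyridin-3-yl, also departs from the only earlier group with a read number, with a 2.1-fold lower number from compound 2 to compound 4 (0.31 log units; beyond the scatter) against 4-chlorophenyl, and from 4-(methylsulfonyl)phenyl with an at least 2.7-fold lower number from compound 3 to compound 4 (0.44 log units; beyond the scatter) as its step, so compound 4 stands as the strongest of the four compounds shown, with all its steps beyond the scatter. Within the data shown here, only the step against 4-chlorophenyl has a fixed size, and the other two are floors because they start from a limit of the assay: (the limit of > 100000 nM in this assay, at which 2 of the 4 values shown sit).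

Going by these compounds, whether the step needs chloro itself stays open, since a methyl group, a methoxy group or an amine in that place on the pyridin-3-yl ring would separate the effect of chloro from that of any other group there. Also open, on these data alone, is whether a second chloro or a fluoro on the 4-chlorophenyl ring, or a carboxylic acid on either ring, would move the number in this assay on the shared core.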